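A few compounds are considered here, and "the series" means these few. Any claim that something is new, unique, unknown or untested is made for them only; others in the source may bear on it.

Measured compounds, an assay on CHO cells for displacement of a labelled ligand from adenosine receptor A3 (Homo sapiens), read by scintillation counting, with a stated time of 60 min; on this read-out lower numbers stand for stronger inhibition and higher numbers for weaker inhibition:

Compound 2, `Cc1ccc(-c2nc(N)c3nn(-c4ccccc4)cc3n2)o1`: compound 2 gives 147 nM.
Compound 1, `Cc1ccc(-c2nc(N)c3nn(-c4ccccc4O)cc3n2)o1`: compound 1 gives 375 nM.
Compound 3, `Nc1nc(-c2ccco2)nc2cn(Cc3ccccc3O)nc12`: compound 3 gives 905 nM.

Compound 2 stands lowest of the three numbers in this assay. Among the compounds with values here, the one single-point step in the set is a 2.6-fold lower number from compound 1 to compound 2 (0.41 log units; beyond the scatter), so removing the hydroxy from the phenyl on the core of compound 1 gives a modest gain. Compound 3 differs from compound 2 in more than one place and its value is simply the highest of the three.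

Compound 4, `COc1ccccc1-n1cc2nc(-c3ccc(C)o3)nc(N)c2n1`, differs from compound 2 by methoxy in place of hydrogen on an aromatic carbon. Within the data shown here, no measured step covers a methoxy at this carbon; the only step that bears on it is a 2.6-fold lower number from compound 1 to compound 2 (0.41 log units; beyond the scatter), where a hydroxy at the same carbon, ortho to the same large group, gave the higher number. Among the measured compounds shown here, that step is modest and its direction is the only guide available. On that basis a modest step upward is expected for a 2.0-fold higher number from compound 2 to compound 4 (0.31 log units; beyond the scatter), with a real chance that it stays within the scatter. The number estimated for compound 4 in this assay is 300 nM, within a range of 120 nM to 800 nM.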

Compound 4, inhibition constant: 297 nM
The estimate for compound 4 lay 1.0-fold (0.00 log units) above the measured number, within the range that was stated.
By their numbers in this assay, from the lowest: compound 2; then compounds 4 and 1 (each within the scatter of the next); then compound 3.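

In this assay, the aromatic carbon ortho to a large group now has a second substituent to compare with hydrogen: a 2.0-fold higher number from compound 2 to compound 4 (0.31 log units; beyond the scatter) shows that methoxy, like the hydroxy of compound 1, goes with a higher number than the unsubstituted phenyl of compound 2. Capping the oxygen adds little to this picture, as a 1.3-fold lower number from compound 1 to compound 4 (0.10 log units; within the scatter) leaves compound 1 and compound 4 indistinguishable on this read-out, so methyl in place of hydrogen on that oxygen has no effect that can be read here. Nothing shown gives a reason for either step, and no supporting data bear on them.

Going by these compounds, it remains open whether the higher number follows from any group at this carbon or only from groups attached through oxygen; a chlorine, an amine or a longer ether such as ethoxy would help to separate these cases. Also open, on these data alone, is whether methoxy on other carbons of the same phenyl gives a number close to that of compound 2 or close to that of compound 4.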